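One phosphorus unit fewer on compound 1

The source may hold more compounds than are shown below. What is called first, only, known or untested is meant among the compounds shown, and "the series" means these compounds.

Measured in an in vitro functional assay on 1321-N1 cells for agonist activity at P2Y purinoceptor 4 (Homo sapiens); a lower number here means that less compound is needed, a higher number that more compound is needed for the effect:
compound 1 `Cn1c(=O)ccn([C@@H]2O[C@H](COP(=O)(O)OP(=O)(O)OP(=O)(O)O)[C@@H](O)[C@H]2O)c1=O` gives 2920 nM
compound 2 `O=c1[nH]c(=O)n([C@@H]2O[C@H](COP(=O)(O)OP(=O)(O)OP(=O)(O)O)[C@@H](O)[C@H]2O)cc1Br` gives 3460 nM
compound 3 `Cc1cc(=O)n([C@@H]2O[C@H](COP(=O)(O)OP(=O)(O)OP(=O)(O)O)[C@@H](O)[C@H]2O)c(=O)[nH]1` gives > 100000 nM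

Compound 1 and compound 2 sit within the scatter of each other, as a 1.2-fold higher number from compound 1 to compound 2 (0.07 log units; within the scatter) shows. Compound 3 gives only a limit, > 100000 nM. The steps of an at least 34-fold higher number from compound 1 to compound 3 (1.53 log units; beyond the scatter) and an at least 28-fold higher number from compound 2 to compound 3 (1.46 log units; beyond the scatter) are large and end at the limit (the limit of > 100000 nM in this assay, at which 1 of the 3 values shown sits).

Compound 4 `Cn1c(=O)ccn([C@@H]2O[C@H](COP(=O)(O)OP(=O)(O)O)[C@@H](O)[C@H]2O)c1=O` differs from compound 1 by a hydrogen atom in place of a group of 4 heavy atoms (3 oxygen, 1 phosphorus; no ring), on an oxygen. None of the three measured steps touches this place; each of them swaps the ring group on the saturated ring carbon and leaves the chain untouched. Within the data shown here, the expectation for a 10-fold higher number from compound 1 to compound 4 (1.01 log units; beyond the scatter) therefore rests on no measured step, and a higher number with a wide range is expected. Compound 4 is estimated at 30000 nM, between 5000 nM and 150000 nM.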

Compound 4, half-maximal effective concentration: > 100000 nM
Compound 4: a limit, no number (the forecaster's own chance of this, stated with the estimate: 35%); at least 3.3-fold (0.52 log units) between middle value and limit.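

With a hydrogen atom in place of the group of 4 heavy atoms (3 oxygen, 1 phosphorus) on an oxygen, the step is an at least 34-fold higher number from compound 1 to compound 4 (1.53 log units; beyond the scatter). This is the first change shown in the chain rather than the ring group, and in this assay it alone is enough to lose a measurable number while the rest of compound 1 stays intact. The value of compound 4 is only a limit, so the full size of the step remains unknown: the limit of > 100000 nM in this assay, at which 2 of the 4 values shown sit.

What the compounds shown leave open is whether a longer chain of phosphorus units or a carboxylic acid on that oxygen would lower or raise the number relative to compound 1.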